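Pyridin-2-yl for furan-2-yl on the shared core

This account rests on a few compounds, and the source may have more. Where it says the series, first, only, none or still open, it means among the compounds named here.

Of the compounds shown here, two carry numbers so far, compound 1 (`Oc1cccc(-c2cc(-c3ccccc3)nc(-c3cccs3)c2)c1`) and compound 2 (`Oc1cccc(-c2cc(-c3ccccc3)nc(-c3ccco3)c2)c1`). In a functional assay on DU-145 cells (Homo sapiens) for cytotoxicity, read by ELISA, with a stated time of 2 days (a higher number here means a weaker inhibitor, a lower number a stronger inhibitor), compound 1 gives 19700 nM and compound 2 gives 34900 nM. Going by the values given here, compound 2 therefore stands within the scatter of its only measured neighbour, and the series so far shows no real separation.

The next structure is compound 3 (`Oc1cccc(-c2cc(-c3ccccc3)nc(-c3ccccn3)c2)c1`), with pyridin-2-yl in place of furan-2-yl on an aromatic carbon, next to the ring nitrogen: pyridin-2-yl in place of furan-2-yl on an aromatic carbon.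

Among the compounds with values here, only one measured step bears on this change: a 1.8-fold higher number from compound 1 to compound 2 (0.25 log units; within the scatter). That step swaps one five-membered aromatic ring for another at the same place. Within the data shown here, no measured step brings a six-membered aromatic ring to this place, so it offers only a loose guide, and the range must stay wide. No shift beyond the scatter is expected, and no direction is firmly expected. The estimated step is a 1.4-fold lower number from compound 2 to compound 3 (0.14 log units; within the scatter). In this assay the estimated value for compound 3 is 25000 nM, with an expected range of 9000 nM to 70000 nM.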

Compound 3, half-maximal inhibitory concentration: 15500 nM
Beside the measured number, compound 3's estimate is 1.6-fold (0.21 log units) above it; low and high end bracket the measured number.
By their numbers in this assay, from the lowest: compounds 3, 1 and 2 (each within the scatter of the next, the first and the last beyond it).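

Going by these compounds alone, this position takes a six-membered aromatic ring without any loss: in this assay the change from furan-2-yl to pyridin-2-yl gives a 2.3-fold lower number from compound 2 to compound 3 (0.35 log units; beyond the scatter) and is the first step to clear the scatter. Set against thiophen-2-yl, the same ring gives a 1.3-fold lower number from compound 1 to compound 3 (0.10 log units; within the scatter) and so the two cannot be told apart here. The only separation in the series therefore lies between the furan-2-yl and pyridin-2-yl compounds, while compound 1 stays within the scatter of both, and the whole pattern rests on a single modest step.

As far as these compounds go, all three compounds carry an aromatic ring with one hetero atom at this place, so it remains open how a group of another kind, such as an amine, a carboxylic acid or a longer alkyl chain, would read here. The 3-hydroxyphenyl and phenyl groups are also the same throughout, which leaves their contribution to the numbers open as well.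

Nothing shown here offers an explanation for the step from furan-2-yl to pyridin-2-yl.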